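Swapping a Dimethoxyphenyl for a Bromophenyl on a Shared Core

A few compounds are considered here, and "the series" means these few. Any claim that something is new, unique, unknown or untested is made for them only; others in the source may bear on it.

Measured compounds:
compound 1 `COc1ccc2c(c1)c(-c1nc3ccccc3n1C(=O)c1ccc(OC)c(OC)c1)cn2C` gives 5100 nM
compound 2 `COc1ccc2c(c1)c(-c1nc3ccccc3n1C(=O)c1ccccc1Br)cn2C` gives 54200 nM
compound 3 `COc1ccc(C(=O)n2c(-c3cn(C)c4ccc(Br)cc34)nc3ccccc32)cc1OC` gives 9700 nM

All three values come from a functional assay on HepG2 cells (Homo sapiens) for inhibition, read by MTT assay, with a stated time of 24 h; a higher number here means a weaker inhibitor of growth, a lower number a stronger inhibitor of growth. Compound 1 and compound 2 share one core and differ at a single spot: 2-bromophenyl in place of 3,4-dimethoxyphenyl on a carbonyl carbon. That exchange produced an 11-fold higher number from compound 1 to compound 2 (1.03 log units; beyond the scatter), a clear loss of growth inhibition.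

Compound 3 carries a slightly altered core. Its difference from compound 1 is bromo in place of methoxy on an aromatic carbon, and the resulting 1.9-fold higher number from compound 1 to compound 3 (0.28 log units; within the scatter) means the two cannot be told apart by this assay.

Compound 4 `Cn1cc(-c2nc3ccccc3n2C(=O)c2ccccc2Br)c2cc(Br)ccc21` has not yet been measured. It stands to compound 3 exactly as compound 2 stands to compound 1: 2-bromophenyl in place of 3,4-dimethoxyphenyl on a carbonyl carbon. The surroundings of the change are the same in both pairs, so this is the same change made on a core that differs only by the bromo-for-methoxy exchange just described.

The expectation is that compound 4 will follow compound 2 and move in the direction of weaker growth inhibition. Among the compounds with values here, for compound 4 the expected step is a 9.8-fold higher number from compound 3 to compound 4 (0.99 log units; beyond the scatter), resting on the one measured instance of this change, where compound 1 to compound 2 gave an 11-fold higher number from compound 1 to compound 2 (1.03 log units; beyond the scatter), and on compound 3 starting from 9700 nM. With a single precedent the range is kept wide. Compound 4 is therefore estimated at 95000 nM in this assay, expected to lie between 30000 nM and 250000 nM.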

Compound 4, concentration for 50% growth inhibition: 72100 nM
The estimate for compound 4 lay 1.3-fold (0.12 log units) above the measured number; measured number inside the range.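

In this assay, putting 2-bromophenyl in place of 3,4-dimethoxyphenyl on the carbonyl carbon of compound 3 gave a 7.4-fold higher number from compound 3 to compound 4 (0.87 log units; beyond the scatter), so the clear loss of growth inhibition seen on the core of compound 1 appeared again, and the two steps agree: the same change on two cores in this assay, an 11-fold higher number (1.03 log units; beyond the scatter) from compound 1 to compound 2 and a 7.4-fold higher number (0.87 log units; beyond the scatter) from compound 3 to compound 4, 1.4-fold (0.16 log units) apart, within the scatter of two such steps

The other exchange, bromo in place of methoxy on an aromatic carbon, gave a 1.3-fold higher number from compound 2 to compound 4 (0.12 log units; within the scatter) with the 2-bromophenyl group present, and this matches what the same exchange did with the 3,4-dimethoxyphenyl group present: the same change on two cores in this assay, a 1.9-fold higher number (0.28 log units; within the scatter) from compound 1 to compound 3 and a 1.3-fold higher number (0.12 log units; within the scatter) from compound 2 to compound 4, 1.4-fold (0.16 log units) apart, within the scatter of two such steps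

Within the data shown here, in this small set, then, the effect of each change can be carried from one core to the other, but this rests on only two pairs of steps in one cell line, and it shows neither that the pattern would hold on other cores nor why the 2-bromophenyl compounds are weaker.

The compounds shown cannot separate the effect of gaining the bromine from that of losing the two methoxy groups, and a plain phenyl on the carbonyl carbon would be needed to pull those apart. As far as these compounds go, how an amine or a nitrile would behave in place of the bromo or methoxy group on the core also remains open.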